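A few compounds are considered here, and "the series" means these few. Any claim that something is new, unique, unknown or untested is made for them only; others in the source may bear on it.

Compound 2, `CCC(C)[C@H](NC(=O)[C@]1(O)C[C@@H](O)[C@@H](O)[C@H](O)C1)C(=O)O`, is the compound with the higher number of the two measured here: in an assay on HL-60 cells for inhibition of P-selectin (Homo sapiens), tested at 50 mM (a higher number here means more inhibition at the concentration tested (going by the name of the read-out), a lower number less inhibition), compound 2 gives 92%. Compound 1, `O=C(O)CC[C@H](NC(=O)[C@]1(O)C[C@@H](O)[C@@H](O)[C@H](O)C1)C(=O)O`, gives 86% in this assay, and the step of a number 6 percentage points higher from compound 1 to compound 2 (within the scatter) lies within the scatter, so the two compounds cannot be told apart on these numbers. Compound 3, `O=C(O)[C@H](CO)NC(=O)[C@]1(O)C[C@@H](O)[C@@H](O)[C@H](O)C1`, has not been measured yet. It differs from compound 2 in one place: hydroxymethyl in place of sec-butyl on a saturated chain carbon bound to an amide-type nitrogen and a carbonyl carbon. Among the measured compounds shown here, the only measured step that bears on this one is the exchange of side chains at the same position, a number 6 percentage points higher from compound 1 to compound 2 (within the scatter), which changed nothing beyond the scatter; both measured compounds sit near the top of the percentage scale. The expected step is therefore a number 5 percentage points lower from compound 2 to compound 3 (within the scatter), meaning none beyond the scatter. Compound 3 is expected to give about 87% in this assay, with a range from 70% to 100%.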

Compound 3, a percentage reported as inhibition, at one concentration (the size of the read-out at that concentration, not a potency): 88%
The estimate for compound 3 lay 1 percentage points below the measured number; the measured number falls inside the stated range.
By their numbers in this assay, from the lowest: compounds 1, 3 and 2 (each within the scatter of the next).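

In this assay, hydroxymethyl with 2 heavy atoms in place of sec-butyl with 4 heavy atoms gives a number 4 percentage points lower from compound 2 to compound 3 (within the scatter), so a side chain with a hydrogen-bond donor and acceptor cannot be told apart from an all-carbon one here. The comparison with the carboxylic acid side chain, hydroxy in place of carboxymethyl, gives a number 2 percentage points higher from compound 1 to compound 3 (within the scatter), which means that all three side chains now tested at this position fall within the scatter of one another. Nothing available explains why these different side chains give such similar readings.

As far as these compounds go, whether a side chain carrying an amine or a phenyl ring would also stay within this range remains open. From the compounds shown here alone, each reading comes from a single concentration and is not a potency, so differences at lower concentrations also remain open.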